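Benzyl to 4-fluorobenzyl: a step starting from a limit

This account rests on a few compounds, and the source may have more. Where it says the series, first, only, none or still open, it means among the compounds named here.

In a functional assay on RAW264.7 cells (Mus musculus) for inhibition, read by Griess assay, with stated times of 1 h and 24 h (on this read-out higher numbers stand for weaker inhibition and lower numbers for stronger inhibition), compound 1 `CCCCCCOc1ccc(C(O)C2OC(=O)c3c(OC)cc(OC)cc32)cc1` gives 5360 nM. Compound 2 `COc1cc(OC)c2c(c1)C(C(O)c1ccc(OCc3ccccc3)cc1)OC2=O` reads > 10000 nM, which is a limit of the assay and not a number. Compound 2 therefore has no exact place on the scale, and any comparison with it has only a limit to start from.

Compound 3 `COc1cc(OC)c2c(c1)C(C(O)c1ccc(OCc3ccc(F)cc3)cc1)OC2=O` differs from compound 2 in one place: fluoro in place of hydrogen on an aromatic carbon. This is fluoro in place of hydrogen on an aromatic carbon, para to a large group, which turns the benzyl into 4-fluorobenzyl. Among the measured compounds shown here, only one measured step touches this end of the molecule, an at least 1.8-fold higher number from compound 1 to compound 2 (0.27 log units; that floor lies within the scatter). That step is a different change, phenyl in place of pentyl, and its size is only a floor within the scatter. For the measured compounds named here, no measured step shows what fluoro in place of hydrogen does, so no shift beyond the scatter is expected in this assay. The expected step is a step that the limit leaves unreadable from compound 2 to compound 3, and another reading at the limit would be no surprise. Compound 3 is estimated at 11000 nM, with an expected range of 5000 nM to 25000 nM.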

Compound 3, half-maximal inhibitory concentration: 760 nM
Compound 3: the middle estimate sits 14-fold (1.16 log units) above what was measured; the measured number lies below the stated range.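

In this assay, among the compounds shown here, fluoro in place of hydrogen on an aromatic carbon, para to a large group, gives an at least 13-fold lower number from compound 2 to compound 3 (1.11 log units; beyond the scatter), so this end of the molecule answers strongly to one small change, which the earlier compounds, with their single floor within the scatter, could not show. Compound 2 reads > 10000 nM, which is a limit of the assay and not a number, so the step from it gives only a floor and its true size stays unread: the limit of > 10000 nM in this assay, at which 1 of the 3 values shown sits. The 4-fluorobenzyl group also compares favourably with the chain of the first compound, at a 7.1-fold lower number from compound 1 to compound 3 (0.85 log units; beyond the scatter), which shows that an aromatic group at this end of the molecule can go with a clearly lower number than that chain, even though the unsubstituted benzyl gave no such sign.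

The compounds shown leave open whether the step belongs to fluoro alone or would also appear with chloro, methyl or methoxy at this same place. They also leave open what an amine or a carboxylic acid there would do, and the data give no reason for the size of the step.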